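A few compounds are considered here, and "the series" means these few. Any claim that something is new, unique, unknown or untested is made for them only; others in the source may bear on it.

Compound 1 `COc1nn(Cc2ccccc2)c(=O)o1` is the unsubstituted parent of this small set. In an assay on COS-7 cells for inhibition of Fatty-acid amide hydrolase 1 (Homo sapiens), read by scintillation counting, with a stated time of 10 min, tested at 10 uM (on this read-out higher numbers stand for more inhibition at the one concentration tested (going by the name of the read-out) and lower numbers for less inhibition), compound 1 gives "not active" (no number reported), so no single number fixes where it stands. Two measured relatives carry a group on the six-membered aromatic ring: in this assay compound 2 `COc1nn(Cc2ccccc2[N+](=O)[O-])c(=O)o1` gives 36%, and compound 3 `COc1nn(Cc2ccccc2N)c(=O)o1` gives 8%. Among the measured compounds shown here, the one measured step, a number 28 percentage points lower from compound 2 to compound 3 (beyond the scatter), shows that exchanging one ring substituent for another moves the read-out by a modest amount. Compound 4 `COc1nn(Cc2ccc(NC(C)=O)cc2)c(=O)o1` differs from compound 1 by acetamido in place of hydrogen on an aromatic carbon. For the measured compounds named here, no measured step covers adding a group to compound 1 itself, and weak inhibition is expected because compound 3 gives 8%. Compound 4 is therefore estimated at about 10% in this assay, within 0% to 30%.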

Compound 4, a percentage reported as inhibition, at one concentration (the size of the read-out at that concentration, not a potency): 37%
The estimate for compound 4 lay 27 percentage points below the measured number, outside the stated range (above it).
By their numbers in this assay, from the lowest: compound 3; then compounds 2 and 4 (each within the scatter of the next).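

Among the compounds shown here, compound 1 has no reported number, so no step from it to compound 4 can be read. Nothing shown here accounts for the value of compound 4. The compounds shown leave open how much acetamido itself changes inhibition on the core of compound 1.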